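The source may report more compounds than this note shows. Statements on the series, on what has been measured and on what is new or still open speak of the compounds shown alone.

Compound 1 `CN(C)C(=O)c1cc2cnc(Nc3ccc(N)cn3)nc2n1C1CCCC1`: 68%
Compound 2 `CN(C)C(=O)c1cc2cnc(Nc3ccc(NC(=O)C4(C(=O)Nc5cccc(O)c5)CC4)cc3)nc2n1C1CCCC1`: 86%
Compound 3 `CN(C)C(=O)c1cc2cnc(Nc3ccc(NC(=O)C4(C(=O)Nc5ccc(Cl)c(C(F)(F)F)c5)CC4)cc3)nc2n1C1CCCC1`: 48%

In a functional assay on OVCAR-5 cells (Homo sapiens) for inhibition, read by CCK-8 assay, with a stated time of 72 h, tested at 10 uM (a lower number here means less inhibition of growth, a higher number more inhibition of growth at the concentration tested), compound 2 gives 86%, the highest of the three numbers. Compound 4 `CN(C)C(=O)c1cc2cnc(Nc3ccc(NC(=O)C4(C(=O)Nc5cccc(Br)c5)CC4)cc3)nc2n1C1CCCC1` changes it in one place: bromo in place of hydroxy on an aromatic carbon. This puts bromo in place of hydroxy on an aromatic carbon, meta to a large group. Among the measured compounds shown here, the one measured step that bears on this is a number 38 percentage points lower from compound 2 to compound 3 (beyond the scatter), with 4-chloro-3-(trifluoromethyl)phenyl in place of 3-hydroxyphenyl on an amide-type nitrogen. For the measured compounds named here, that step also lost the hydroxy, but the ring of compound 4 gains only a bromo, and no measurement yet shows what a bromo alone does. A smaller step in the same direction is expected: a number 21 percentage points lower from compound 2 to compound 4 (beyond the scatter). The estimate for compound 4 is 65%, with an expected range of 45% to 85%.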

Compound 4, percent growth inhibition at one concentration: 89.6%
Compound 4: middle estimate off by 24.6 percentage points, on the low side; measured number above the stated range.
By their numbers in this assay, from the lowest: compound 3; then compound 1; then compounds 2 and 4 (each within the scatter of the next).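

In this assay, bromo can replace hydroxy on this ring with a number 3.6 percentage points higher from compound 2 to compound 4 (within the scatter), so at this concentration the hydroxy and its hydrogen-bond donor are not required for growth inhibition. With the hydroxy absent on both sides, there is a number 41.6 percentage points higher from compound 3 to compound 4 (beyond the scatter). The low number of compound 3 goes with the 4-chloro-3-(trifluoromethyl)phenyl group. No measurement here explains these numbers. Still open, from the compounds shown here alone, is whether an amine or a methoxy at this place would hold up as well, and whether chloro or trifluoromethyl alone accounts for the drop seen with compound 3.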